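Dropping one methoxy from an inactive compound

This account rests on a few compounds, and the source may have more. Where it says the series, first, only, none or still open, it means among the compounds named here.

For the measured compounds named here, in a functional assay on PC-3 cells (Homo sapiens) for inhibition, read by sulforhodamine B assay, with a stated time of 48 h, tested at 50 uM (on this read-out higher numbers stand for more inhibition of growth at the one concentration tested and lower numbers for less inhibition of growth), compound 1 (`COc1cc(/C=C/C(=O)/C=C/c2cccc3ccccc23)ccc1OCc1cn(CCOc2cc(=O)oc3ccccc23)nn1`) gives 20% and carries the only number among the three compounds measured so far. Compound 2 (`COc1ccc(/C=C/C(=O)/C=C/c2ccc(OCc3cn(CCCCOc4cc(=O)oc5ccccc45)nn3)c(OC)c2)cc1OC`) is reported as "not active" (no number reported) without a figure. Compound 3 (`COc1cccc(/C=C/C(=O)/C=C/c2ccc(OCc3cn(CCCOc4cc(=O)oc5ccccc45)nn3)c(OC)c2)c1`) is reported as "not active" (no number reported) in the same way, so it has no place on a numerical scale and shares that position with compound 2.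

Compound 4 (`COc1cc(/C=C/C(=O)/C=C/c2ccccc2)ccc1OCc1cn(CCCOc2cc(=O)oc3ccccc23)nn1`) has not yet been measured. It differs from compound 3 by a single change (hydrogen in place of methoxy on an aromatic carbon): hydrogen in place of methoxy on an aromatic carbon, meta to a large group, which turns the 3-methoxyphenyl into phenyl. Going by the values given here, no measured pair in this small set differs in one place only, so the data offer no direct guide to this change. In this assay compound 4 is expected to stay close to compound 3, with no step beyond the scatter and no favoured direction. Among the compounds with values here, the only available number, compound 1 at 20% as a modest reading, suggests low readings for this set. For compound 4 the estimated value is 10% with an expected range from 0% to 25% if a number is reported at all.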

Compound 4, percent growth inhibition at one concentration: "not active" (no number reported)
Nothing numeric was reported for compound 4; there is nothing to compare the estimate with.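

In this assay compound 3 and compound 4 are both reported as not active, without a number, so no step can be read between them. The compounds shown leave open whether exchanging the methoxy for hydrogen changes growth inhibition at all. No available evidence bears on this result.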